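The source may hold more compounds than are shown below. What is called first, only, known or untested is meant among the compounds shown, and "the series" means these compounds.

Compound 1, `O=S(=O)(c1ccccc1)c1nc2ccccc2nc1N1CCc2ccccc2C1`, gives 5010 nM in a functional assay on PC-3 cells (Homo sapiens) for cytotoxicity, read by MTT assay, with a stated time of 72 h; a higher number here means a weaker inhibitor, a lower number a stronger inhibitor. Compound 2, `O=S(=O)(c1ccc(Br)cc1)c1nc2ccccc2nc1N1CCc2ccccc2C1`, differs only by a bromo group on an aromatic carbon where compound 1 has hydrogen. In this assay compound 2 is reported only as a limit, > 50000 nM, so no exact number exists for it. The step of an at least 9.9-fold higher number from compound 1 to compound 2 (0.99 log units; beyond the scatter) therefore shows a weakening that is at least modest, and its true size is hidden because of the limit of > 50000 nM in this assay, at which 1 of the 2 values shown sits. Compound 3, `O=S(=O)(c1ccc(F)cc1)c1nc2ccccc2nc1N1CCc2ccccc2C1`, has not yet been measured in this assay. Its change from compound 2 is fluoro in place of bromo on an aromatic carbon. Among the measured compounds shown here, only the bromo step bears on this change, and no step with a fluoro group has been measured, so the fluoro compound is expected to land somewhere between compound 1 and the limit of compound 2. Compound 3 is therefore estimated at 15000 nM, within a range from 5000 nM to 50000 nM. The expected step of an at least 3.3-fold lower number from compound 2 to compound 3 (0.52 log units; beyond the scatter) would then be a move toward a stronger inhibitor, though the limit for compound 2 leaves its size uncertain.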

Compound 3, half-maximal inhibitory concentration: 9230 nM
Estimate against measurement, compound 3: 1.6-fold (0.21 log units) above; the measured number falls inside the stated range.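

In this assay, the weakening seen with bromo does not carry over to every replacement at this place on the aromatic ring, para to a large group: fluoro in place of bromo gives an at least 5.4-fold lower number from compound 2 to compound 3 (0.73 log units; beyond the scatter). Fluoro in place of hydrogen gives a 1.8-fold higher number from compound 1 to compound 3 (0.27 log units; within the scatter), so fluoro cannot be told apart from hydrogen here, while bromo stands clearly apart from both. The true size of the bromo-to-fluoro step stays hidden because the bromo value is only a limit: the limit of > 50000 nM in this assay, at which 1 of the 3 values shown sits.

Going by these compounds, whether chloro or methyl at this place would behave like fluoro or like bromo remains open. Also open, on these data alone, is whether a group of another kind here, such as methoxy, an amine or a carboxylic acid, could give a clearly lower number than hydrogen does.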